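The source may hold more compounds than are shown below. What is called first, only, known or untested is meant among the compounds shown, and "the series" means these compounds.

Compound 2, `CNc1nc(NCCCN(C)C)c2sc(-c3cccc(C#N)c3)cc2n1`, was measured in a physicochemical assay for solubility, at pH 2; on this read-out lower numbers stand for lower solubility and higher numbers for higher solubility. In this assay compound 2 gave a reading of > 100 ug/mL, which is a limit of the assay rather than a number. Compound 1, `CNc1nc(NCCCN(C)C)c2cc(-c3ccccc3)sc2n1`, is the other compound measured here; in this assay compound 1 gave 216 ug/mL. Among the compounds with values here, no step between the two measured compounds is computed, and the pair shares only the reading of compound 1 and the limit of compound 2, so their values are stated and not compared further; the limit is noted in the record as the limit of > 100 ug/mL in this assay, at which 1 of the 2 values shown sits.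

Compound 3, `CNc1nc(NCCCN(C)C)c2sc(-c3ccccc3)cc2n1`, is not yet measured. It differs from compound 2 by hydrogen in place of cyano on an aromatic carbon. Within the data shown here, no measured step covers this change, so its size is an expectation only. The step is expected to stay within the scatter or be small, and is estimated as a step that the limit leaves unreadable from compound 2 to compound 3. Compound 3 is therefore expected to give about 200 ug/mL in this assay, with a range from 80 ug/mL to 450 ug/mL. The actual reading for compound 3 remains to be taken.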

Compound 3, solubility: > 100 ug/mL
Compound 3 ended at the assay's limit; the forecaster's own chance of this, stated with the estimate: 40%; the middle value is on the limit's open side.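

In this assay compound 3 gave > 100 ug/mL, which is a limit of the assay and not a number. Compound 2 sits at the same limit, so no step can be read between compound 2 and compound 3: the limit of > 100 ug/mL in this assay, at which 2 of the 3 values shown sit.

The compounds shown leave open whether hydrogen in place of cyano shifts the reading in this assay at all.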